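The compounds below may be only part of what the source reports. "The series", "measured", "known", "first", "only" and "open" are said of these compounds alone.

Compound 3 `O=C1c2c[n+]([O-])c3ccccc3c2C(=O)c2c1c1ccccc1n2CCCCN1CCCCC1` gives the lowest number of the three compounds measured in a functional assay on HCT-116 cells (Homo sapiens) for cytotoxicity, read by MTT assay, with a stated time of 72 h (a lower number here means a stronger inhibitor, a higher number a weaker inhibitor), with compound 3 at 200 nM. Compound 1 `CN1CCN(CCCCCCn2c3c(c4ccccc42)C(=O)c2c[n+]([O-])c4ccccc4c2C3=O)CC1` gives 2900 nM and compound 2 `CN1CCN(CCCCCn2c3c(c4ccccc42)C(=O)c2c[n+]([O-])c4ccccc4c2C3=O)CC1` gives 1220 nM in this assay, so both sit well above compound 3: the step of a 15-fold lower number from compound 1 to compound 3 (1.16 log units; beyond the scatter) and the step of a 6.1-fold lower number from compound 2 to compound 3 (0.79 log units; beyond the scatter) are each beyond the scatter, and the step of a 2.4-fold lower number from compound 1 to compound 2 (0.38 log units; beyond the scatter) is also beyond it. Compound 4 `O=C1c2c[n+]([O-])c3ccccc3c2C(=O)c2c1c1ccccc1n2CCN1CCCC1` differs from compound 3 in one place: pyrrolidin-1-yl in place of 2-(piperidin-1-yl)ethyl on a saturated chain carbon, two bonds along the chain from an aromatic nitrogen. Among the compounds with values here, no measured step covers a pyrrolidin-1-yl group or a chain this short, so the bearing of the earlier steps is indirect. Those steps ran toward lower numbers as the chain shortened and the terminal ring changed, but the present change goes further than any of them, so no step beyond the scatter is expected in either direction in this assay. Compound 4 is therefore expected to give about 250 nM, within 80 nM to 800 nM, which means an expected step of a 1.3-fold higher number from compound 3 to compound 4 (0.10 log units; within the scatter).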

Compound 4, half-maximal inhibitory concentration: 270 nM
Compound 4: middle estimate off by 1.1-fold (0.03 log units), on the low side, within the range that was stated.
By their numbers in this assay, from the lowest: compounds 3 and 4 (each within the scatter of the next); then compound 2; then compound 1.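

In this assay, replacing 2-(piperidin-1-yl)ethyl with pyrrolidin-1-yl on a saturated chain carbon, two bonds along the chain from an aromatic nitrogen, gives a 1.4-fold higher number from compound 3 to compound 4 (0.13 log units; within the scatter), so shortening the chain and contracting the ring together left the number within the scatter. The low numbers are thus not confined to the piperidin-1-yl group of compound 3, as the gaps to the 4-methylpiperazin-1-yl compounds also show: a 4.5-fold lower number from compound 2 to compound 4 (0.65 log units; beyond the scatter) and an 11-fold lower number from compound 1 to compound 4 (1.03 log units; beyond the scatter). Nothing available bears on the reason for these steps.

Going by these compounds, in the steps to compound 4, chain and terminal ring change together, so the separate contribution of each remains open. Also open, on these data alone, is how piperidin-1-yl would read on the shorter chain of compound 4, pyrrolidin-1-yl on the longer chain of compound 3, or a morpholine ring on either chain.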